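This account rests on a few compounds, and the source may have more. Where it says the series, first, only, none or still open, it means among the compounds named here.

Among the compounds with values here, in a physicochemical assay for lipophilicity, measured as octanol-water partition (on this read-out lower numbers stand for lower lipophilicity and higher numbers for higher lipophilicity), three compounds built on a shared core have numbers so far. Compound 1 `N#Cc1c(-c2ccco2)[n+]([O-])c2ccc(F)cc2[n+]1[O-]` gives 0.983 in this test, and compound 2 `N#Cc1c(-c2ccco2)[n+]([O-])c2ccc(C(F)(F)F)cc2[n+]1[O-]` gives 1.5 on the same scale. Compound 3 `COc1ccc2c(c1)[n+]([O-])c(C#N)c(-c1ccc(Cl)cc1)[n+]2[O-]` gives 2.09 and so holds the highest number of the three, beyond the scatter from both of the others.

The next compound to be measured is compound 4 `COc1ccc2c(c1)[n+]([O-])c(C#N)c(-c1ccc(C)cc1)[n+]2[O-]` and it differs from compound 3 in one place: methyl in place of chloro on an aromatic carbon that is, methyl in place of chloro on an aromatic carbon, or 4-chlorophenyl to 4-methylphenyl when cut one bond further out.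

Within the data shown here, only one measured step involves a single swap: a number 0.52 log units higher from compound 1 to compound 2 (beyond the scatter) for trifluoromethyl in place of fluoro on an aromatic carbon. That modest step involves a different pair of groups in a different setting, so it bears on this change only loosely. Among the measured compounds shown here, no measured pair swaps chloro for methyl. Nothing here points to a step as large as that one, so in this assay only a slight fall is expected. The estimated step is a number 0.14 log units lower from compound 3 to compound 4 (within the scatter) and it is expected to stay within the scatter. For compound 4 the estimated value is 1.95 with an expected range from 1.6 to 2.3 as the likely span.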

Compound 4, partition coefficient: 1.83
The estimate for compound 4 lay 0.12 log units above the measured number; the measured number falls inside the stated range.
By their numbers in this assay, from the lowest: compound 1; then compound 2; then compounds 4 and 3 (each within the scatter of the next).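

In this assay, within the data shown here, this pair gives the first direct reading of methyl in place of chloro, on an aromatic carbon para to a large group, and the result is a number 0.26 log units lower from compound 3 to compound 4 (within the scatter). At this position the two groups, each a single heavy atom with no hydrogen-bond donors or acceptors, cannot be told apart by this measurement, whereas the only other single swap shown, trifluoromethyl in place of fluoro on an aromatic carbon, gives a number 0.52 log units higher from compound 1 to compound 2 (beyond the scatter). Nothing available bears on the reason for this result.

This single pair leaves open whether methyl and chloro would also read alike at another place on the shared core, or with a different group at the other positions that vary among these compounds. It also leaves open how far the number can move at this para position, since an amine, a carboxylic acid or a longer chain there could give a step beyond the scatter or one that stays within it.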